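Methoxy in Place of Hydrogen: Compound 1 to Compound 4

The source may report more compounds than this note shows. Statements on the series, on what has been measured and on what is new or still open speak of the compounds shown alone.

Compound 1 `Oc1ccc(C#C/C=C/COc2ccc(O)cc2)cc1` — < 18000 nM
Compound 2 `C=C[C@H](/C=C\c1ccc(O)cc1)c1ccc(O)cc1` — 58100 nM
Compound 3 `C=CC(/C=C\c1ccc(O)cc1)c1ccc(OC)c(O)c1` — 12000 nM

In an ADME assay on cells (Homo sapiens) for cytotoxicity (a higher number here means that more compound is tolerated, a lower number that less compound is tolerated), compound 1 gives only a limit, < 18000 nM, and no number. In this assay compound 2 gives 58100 nM and compound 3 gives 12000 nM. Since compound 1 stands at the limit of < 18000 nM in this assay, at which 1 of the 3 values shown sits, its place among the three cannot be fixed more closely than that.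

Compound 4 `COc1cc(C#C/C=C/COc2ccc(O)cc2)ccc1O` has not yet been measured in this assay. It differs from compound 1 by methoxy in place of hydrogen on an aromatic carbon. Within the data shown here, with compound 1 known only as a limit, no measured step supports a direction, so the change from compound 1 to compound 4 is expected to stay within the scatter, a step that the limit leaves unreadable from compound 1 to compound 4. Compound 4 is therefore expected to give about 12000 nM, plausibly between 4000 nM and 30000 nM.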

Compound 4, half-maximal cytotoxic concentration: < 17000 nM
Compound 4 was reported as a limit; the forecaster's own chance of this, stated with the estimate: 40%; the middle value does not contradict the limit.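

Among these compounds, compound 1 and compound 4 are both reported only as limits in this assay, and no step between them can be read. The compounds shown leave open whether methoxy in place of hydrogen on an aromatic carbon changes the tolerated concentration, and in which direction.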